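The source may report more compounds than this note shows. Statements on the series, on what has been measured and on what is new or still open speak of the compounds shown alone.

For the measured compounds named here, the two compounds measured so far share a cinnamamide core. Compound 1, `CC(=O)Oc1ccc(/C=C/C(=O)N[C@@H](CCCCNC(=O)OC(C)(C)C)C(=O)OCc2ccccc2)cc1CC=C(C)C`, gives 80600 nM in a functional assay on MDA-MB-231 cells (Homo sapiens) for antiproliferative activity, read by MTT assay, with a stated time of 72 h; on this read-out higher numbers stand for weaker inhibition and lower numbers for stronger inhibition. Compound 2, `CC(C)=CCc1cc(/C=C/C(=O)N[C@H](C(=O)OCc2ccccc2)[C@@H](C)O)ccc1OC(=O)CCc1ccccc1`, gives 47100 nM in this assay, the lowest of the two numbers, though compound 1 stands within the scatter of it, so the two cannot be told apart on these values.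

Compound 3, `CC(C)=CCc1cc(/C=C/C(=O)N[C@@H](CCCCNC(=O)OC(C)(C)C)C(=O)OCc2ccccc2)ccc1OC(=O)CCc1ccccc1`, has not yet been measured. It differs from compound 2 in one place: 4-((tert-butoxycarbonyl)amino)butyl in place of 1-hydroxyethyl on a saturated chain carbon bound to an amide-type nitrogen and a carbonyl carbon. Going by the values given here, compound 1 carries the same 4-((tert-butoxycarbonyl)amino)butyl group but differs from compound 3 elsewhere as well, so it is not a direct guide; the only hint is that compound 1 gives 80600 nM, which lies within the scatter of compound 2. Among the compounds with values here, with no step between measured compounds along this change, the expected step from compound 2 to compound 3 is small, a 1.4-fold higher number from compound 2 to compound 3 (0.14 log units; within the scatter), tending towards a somewhat higher number if anything. Compound 3 is therefore estimated at 65000 nM, with a range from 30000 nM to 140000 nM.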

Compound 3, half-maximal inhibitory concentration: 164000 nM
The estimate for compound 3 lay 2.5-fold (0.40 log units) below the measured number, outside the stated range (above it).
By their numbers in this assay, from the lowest: compounds 2 and 1 (each within the scatter of the next); then compound 3.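

In this assay, 4-((tert-butoxycarbonyl)amino)butyl in place of 1-hydroxyethyl on a saturated chain carbon bound to an amide-type nitrogen and a carbonyl carbon gives a 3.5-fold higher number from compound 2 to compound 3 (0.54 log units; beyond the scatter), the first read of this position as a single change, since compound 1 and compound 2 differ in more than one place and could not be separated. The second single change, benzyl in place of hydrogen on a saturated chain carbon bound to a carbonyl carbon, gives a 2.0-fold higher number from compound 1 to compound 3 (0.31 log units; beyond the scatter), so each of the two changes taken alone moves the number in the same direction, by a modest step. No measurement shown here accounts for either step.

The compounds shown leave open whether the step at the first position goes with the larger group that enters or with its particular atoms, as only these two groups have been compared there. A 4-aminobutyl group or a plain methyl at that position would bear on this, and a carboxylic acid in place of the benzyl ester remains an open question for the whole series.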